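The source may report more compounds than this note shows. Statements on the series, on what has been measured and on what is new or still open speak of the compounds shown alone.

Measured so far:
compound 1, `O=C(N[C@@H](CO)C(=O)NO)c1ccc(C#Cc2ccccc2)cc1`, 28000 nM
compound 2, `CC(C)(NC(=O)c1ccc(C#Cc2ccccc2)cc1)C(=O)NO`, 182000 nM

Both were measured in a physicochemical assay for solubility; on this read-out lower numbers stand for lower solubility and higher numbers for higher solubility. Compound 2 stands at the highest of the two numbers; its nearest neighbour is compound 1, which shows a 6.5-fold higher number from compound 1 to compound 2 (0.81 log units; beyond the scatter). Among the measured compounds shown here, that step exchanged one group of seven heavy atoms for another on the amide-type nitrogen and is the only measured step here.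

Compound 3, `CC(C)C(NC(=O)c1ccc(C#Cc2ccccc2)cc1)C(=O)NO`, has not yet been measured in this assay. It differs from compound 2 by 1-(hydroxycarbamoyl)-2-methylpropyl in place of 1-(hydroxycarbamoyl)-1-methylethyl on an amide-type nitrogen. For the measured compounds named here, no measured step bears directly on this exchange: the one step known, from compound 1 to compound 2, concerns a different pair of groups at the same amide-type nitrogen, so it gives only a sense of how far numbers can move. With one more carbon entering and the same count of donors and acceptors, a small decrease toward compound 1 is expected, likely not beyond the scatter, amounting to a 1.8-fold lower number from compound 2 to compound 3 (0.26 log units; within the scatter). In this assay compound 3 is therefore estimated at 100000 nM, within a range from 40000 nM to 250000 nM.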

Compound 3, solubility: 7000 nM
For compound 3 the middle estimate is 14-fold (1.15 log units) above the measured one; the measured number lies below the stated range.
By their numbers in this assay, from the lowest: compound 3; then compound 1; then compound 2.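

In this assay, the exchange of 1-(hydroxycarbamoyl)-1-methylethyl for 1-(hydroxycarbamoyl)-2-methylpropyl on the amide-type nitrogen gives a 26-fold lower number from compound 2 to compound 3 (1.41 log units; beyond the scatter), which shows that a change adding one carbon, with donor and acceptor counts unchanged, can move the number further than the earlier step, a 6.5-fold higher number from compound 1 to compound 2 (0.81 log units; beyond the scatter). The new group also stands under the group of compound 1, with a 4.0-fold lower number from compound 1 to compound 3 (0.60 log units; beyond the scatter), so the three groups at this nitrogen now give three numbers separated beyond the scatter, and compound 3 has the lowest of them. Among the compounds shown here, nothing available here explains why this small exchange moves the number so far.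

The compounds shown leave open whether the fall follows the added carbon itself or the way the carbons are arranged in the chain, since only these two hydrocarbon-bearing groups can be compared. They also leave open where a longer chain would fall, and whether a carboxylic acid or an amine on the group at this amide-type nitrogen would bring the number back towards that of compound 2, at 182000 nM.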